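The source may report more compounds than this note shows. Statements on the series, on what has been measured and on what is new or still open speak of the compounds shown alone.

The compounds here share a core carrying two aromatic rings, each bearing a hydroxyl and a methoxy group, joined to a branched saturated chain, and they are compared in a functional assay on HL-60 cells (Homo sapiens) for cytotoxicity, read by WST assay, with a stated time of 48 h; a higher number here means a weaker inhibitor, a lower number a stronger inhibitor. Compound 1 `COC[C@H](C)[C@@H](C)C(c1ccc(O)c(OC)c1)c1ccc(O)c(OC)c1` gives 68000 nM in this assay. Compound 2 `CCCCCCCC[C@H](C(C)C)C(c1ccc(O)c(OC)c1)c1ccc(O)c(OC)c1`, which carries a long saturated chain in place of the shorter branch, gives 3700 nM in this assay. Of the two compounds with a number, compound 1 therefore stands at the higher one, and the gap between them lies beyond the usual scatter. Compound 3 `COc1ccc(C(c2ccc(OC)c(OC)c2)[C@@H](C)[C@@H](C)CO)cc1OC`, in which all four aromatic oxygens are methylated, reaches only the limit of > 100000 nM in this assay, at which 1 of the 3 values shown sits, in this assay, so for compound 3 the value > 100000 nM is a limit and not a number.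

Compound 4 `COc1cc(C(c2ccc(O)c(OC)c2)[C@H](C)[C@H](C)CF)ccc1O` has not yet been measured in this assay. It differs from compound 1 in one place: 1-(fluoromethyl)ethyl in place of 1-(methoxymethyl)ethyl on a saturated chain carbon bound to two saturated chain carbons. The 1-(fluoromethyl)ethyl group is smaller and carries no hydrogen-bond acceptor, while the core and its two aromatic rings are kept. Among the compounds with values here, no measured pair here isolates this exact change, so the size of the step is uncertain. Compound 4 is expected to stay within or slightly below the number of compound 1, with an estimated step of a 1.4-fold lower number from compound 1 to compound 4 (0.13 log units; within the scatter) in this assay. The estimate for compound 4 is 50000 nM, within a range of 15000 nM to 150000 nM.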

Compound 4, half-maximal inhibitory concentration: 56000 nM
Estimate against measurement, compound 4: 1.1-fold (0.05 log units) below; the measured number falls inside the stated range.
By their numbers in this assay, from the lowest: compound 2; then compounds 4 and 1 (each within the scatter of the next). At a limit, above all of these: compound 3.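

Within the data shown here, this is the first pair here that differs in one place only, so a single change on a saturated chain carbon bound to two saturated chain carbons can be read on its own in this assay: 1-(fluoromethyl)ethyl in place of 1-(methoxymethyl)ethyl gives a 1.2-fold lower number from compound 1 to compound 4 (0.08 log units; within the scatter), a step too small to count as a real change. The group that leaves has the higher heavy-atom count and a hydrogen-bond acceptor, while the group that enters has the lower count and no acceptor, yet compound 1 and compound 4 cannot be told apart in this read-out, so at this position the swap leaves cytotoxicity in these cells where it was. Nothing measured here offers a reason for this result.

The compounds shown leave open whether this position would accept a very different end group, such as an amine, a carboxylic acid or a longer chain, as the two groups compared here are both short. Among these compounds, a plain hydroxyl end with both aromatic hydroxyl groups kept also remains open, as the only compound with a hydroxyl end, compound 3, has all four aromatic oxygens methylated and gives only a limit.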